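This account rests on a few compounds, and the source may have more. Where it says the series, first, only, none or still open, it means among the compounds named here.

Working notes on the series. Compound 3 `O=C(O)COc1ccc(Cl)cc1C#Cc1ccccc1Cl` gives 28 nM in an assay on CHO cells for displacement of a labelled ligand from prostaglandin D2 receptor 2 (Homo sapiens), read by scintillation counting; on this read-out lower numbers stand for stronger inhibition and higher numbers for weaker inhibition. Among the three compounds with numbers, compound 3 stands second highest: compound 1 `CC(C)S(=O)(=O)c1ccc(Cl)c(C#Cc2cc(Cl)ccc2OCC(=O)O)c1` gives 2.9 nM in this assay, and compound 2 `O=C(O)COc1ccccc1C#Cc1ccccc1Cl` gives 747 nM in this assay. Two single-point steps are known. One is a 27-fold lower number from compound 2 to compound 3 (1.43 log units; beyond the scatter), chloro in place of hydrogen on an aromatic carbon. The other is a 9.7-fold higher number from compound 1 to compound 3 (0.98 log units; beyond the scatter), hydrogen in place of isopropylsulfonyl on an aromatic carbon.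

Compound 4 `CS(=O)(=O)c1ccc(Cl)c(C#Cc2cc(Cl)ccc2OCC(=O)O)c1` has not yet been measured. It differs from compound 3 by methylsulfonyl in place of hydrogen on an aromatic carbon, a methylsulfonyl in place of hydrogen on an aromatic carbon, meta to a large group and para to a chloro group. Of the measured steps only a 9.7-fold higher number from compound 1 to compound 3 (0.98 log units; beyond the scatter) bears on this: it concerns a sulfonyl group on the same aromatic carbon, runs in the opposite direction, and the group that enters in compound 4 is a smaller relative of the isopropylsulfonyl. A lower number of about that size is therefore expected in this assay, roughly undoing the removal, as a 7.0-fold lower number from compound 3 to compound 4 (0.85 log units; beyond the scatter). For compound 4 the estimate in this assay is 4 nM, with a range from 1.5 nM to 12 nM.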

Compound 4, inhibition constant: 3.5 nM
For compound 4 the middle estimate is 1.1-fold (0.06 log units) above the measured one; low and high end bracket the measured number.
By their numbers in this assay, from the lowest: compounds 1 and 4 (each within the scatter of the next); then compound 3; then compound 2.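

In this assay the methylsulfonyl group, on an aromatic carbon meta to a large group and para to a chloro group, gives an 8.0-fold lower number from compound 3 to compound 4 (0.90 log units; beyond the scatter) and so shows that the lower number at this position does not depend on the isopropylsulfonyl group alone. With methyl in place of isopropyl on the sulfonyl sulfur, the pair shows a 1.2-fold higher number from compound 1 to compound 4 (0.08 log units; within the scatter) and thus no difference beyond the scatter, so these two alkyl groups on the sulfur cannot be told apart on this read-out, and the step from hydrogen to a sulfonyl group now stands on two compounds rather than one. The compounds shown offer nothing that explains the effect of either sulfonyl group at this position.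

The compounds shown leave open whether a group without sulfur on the same aromatic carbon, such as a nitrile or an amide, would give a step of similar size. They also leave open how far the sulfur tolerates change, for instance a phenyl group or a longer chain in place of the methyl, or a sulfonamide in place of the methylsulfonyl.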